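Removing a Methoxy Group from a Cytotoxic Anilide Series

The compounds below may be only part of what the source reports. "The series", "measured", "known", "first", "only" and "open" are said of these compounds alone.

The measured compounds:
compound 1 `COc1cccc(/C=C/C(=O)Nc2cc(OC)c(OC)c(OC)c2)c1` — 11300 nM
compound 2 `COc1cc(NC(=O)/C=C/c2ccccc2)cc(OC)c1OC` — a limit of the assay, > 50000 nM
compound 3 `COc1cc(NC(=O)/C=C/c2ccc(O)cc2)cc(OC)c1OC` — a limit of the assay, > 50000 nM

In a functional assay on HeLa cells (Homo sapiens) for cytotoxicity, read by sulforhodamine B assay, with a stated time of 72 h (on this read-out higher numbers stand for weaker inhibition and lower numbers for stronger inhibition), compound 1 is the only one of the three with a numbered value. Compound 2 sits at the limit of > 50000 nM in this assay, at which 2 of the 3 values shown sit. The change hydrogen in place of methoxy on an aromatic carbon gives an at least 4.4-fold higher number from compound 1 to compound 2 (0.64 log units; beyond the scatter). The change 4-hydroxyphenyl in place of 3-methoxyphenyl on a double-bonded chain carbon bound to a double-bonded chain carbon gives an at least 4.4-fold higher number from compound 1 to compound 3 (0.64 log units; beyond the scatter). Between compounds 2 and 3 there is a step that the two limits leave unreadable from compound 2 to compound 3.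

Compound 4 `COc1cc(NC(=O)/C=C/c2ccc(O)cc2)cc(OC)c1` is not yet measured. It differs from compound 3 by hydrogen in place of methoxy on an aromatic carbon. This is the same kind of change as that from compound 1 to compound 2, though the surroundings differ: in the earlier case the methoxy sat meta to a large group, here it sits ortho to two methoxy groups and para to a large group. Since compound 3 already reaches the limit > 50000 nM and the earlier step was an at least 4.4-fold higher number from compound 1 to compound 2 (0.64 log units; beyond the scatter), compound 4 is expected to stay at or beyond that limit. Compound 4 is estimated at 80000 nM, between 30000 nM and 300000 nM. This estimate means an expected step that the limit leaves unreadable from compound 3 to compound 4, compared with an at least 4.4-fold higher number from compound 1 to compound 2 (0.64 log units; beyond the scatter).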

Compound 4, half-maximal inhibitory concentration: > 50000 nM
Compound 4 was reported as a limit; the forecaster's own chance of this, stated with the estimate: 85%; the middle value does not contradict the limit.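

In this assay compound 4 gives > 50000 nM, which is a limit of the assay. Compound 3 also stands at a limit, so no step can be read between compound 3 and compound 4. The compounds shown leave open how far, if at all, hydrogen in place of methoxy changes cytotoxicity on this pair.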